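The source may hold more compounds than are shown below. What is called first, only, known or untested is meant among the compounds shown, and "the series" means these compounds.

Three measured compounds share one core and differ only at a single aromatic carbon. In a functional assay on the whole organism (6C3HED cells, Mus musculus) for inhibition, at a dose of 150 mg/kg by the oral route (on this read-out higher numbers stand for more inhibition at the one dose given (going by the name of the read-out) and lower numbers for less inhibition), compound 1 `O=C(Nc1ccc(Cl)cc1)NS(=O)(=O)c1cccs1`, bearing hydrogen at that carbon, gives 16%. Compound 2 `CSc1ccc(S(=O)(=O)NC(=O)Nc2ccc(Cl)cc2)s1`, with methylsulfanyl there, gives 29%, a gain of a number 13 percentage points higher from compound 1 to compound 2 (beyond the scatter). Compound 3 `CCOc1ccc(S(=O)(=O)NC(=O)Nc2ccc(Cl)cc2)s1`, with ethoxy there, gives 69%, the highest of the three, standing a number 53 percentage points higher from compound 1 to compound 3 (beyond the scatter) and a number 40 percentage points higher from compound 2 to compound 3 (beyond the scatter).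

Compound 4 `CC(C)c1ccc(S(=O)(=O)NC(=O)Nc2ccc(Cl)cc2)s1` differs from compound 3 by isopropyl in place of ethoxy on an aromatic carbon. Both large gains came with ethoxy, which carries one hydrogen-bond acceptor, whereas methylsulfanyl brought only a number 13 percentage points higher from compound 1 to compound 2 (beyond the scatter). Isopropyl carries no acceptor, so a fall is expected, a number 31 percentage points lower from compound 3 to compound 4 (beyond the scatter). Compound 4 is estimated at 38%, within 18% to 62%.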

Compound 4, a percentage reported as inhibition, in the whole organism at one dose (the size of the read-out at that dose, not a potency): 42%
The estimate for compound 4 lay 4 percentage points below the measured number; the range from low to high includes it.
By their numbers in this assay, from the lowest: compound 1; then compound 2; then compound 4; then compound 3.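

In this assay, isopropyl, which carries no hydrogen-bond acceptor, still beats hydrogen, with a number 26 percentage points higher from compound 1 to compound 4 (beyond the scatter), and methylsulfanyl, with a number 13 percentage points higher from compound 2 to compound 4 (beyond the scatter), so a gain at this carbon does not need an acceptor. Ethoxy stays ahead, with a number 27 percentage points lower from compound 3 to compound 4 (beyond the scatter), even though the two groups have the same count of heavy atoms. Nothing at hand gives a cause for these steps. As far as these compounds go, whether a longer chain such as butoxy, or an amine, at this carbon would match or pass ethoxy stays open.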